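Thioamide series: aryl-to-methyl exchange on the shared core

This account rests on a few compounds, and the source may have more. Where it says the series, first, only, none or still open, it means among the compounds named here.

Measured so far:
compound 1 `N=C(S)CCn1nc(-c2cccs2)ccc1=O` — 50.2%
compound 2 `Cc1cc(=O)n(CCC(=N)S)nc1-c1ccccc1` — 32%

In a functional assay on the whole organism (stomach) for inhibition, with Rattus norvegicus as the target, at a dose of 100 mg/kg by the intraduodenal route (on this read-out lower numbers stand for less inhibition and higher numbers for more inhibition at the one dose given (going by the name of the read-out)), compound 1 stands highest of the two numbers; compound 2 sits lower, a gap beyond the usual scatter. Among the measured compounds shown here, no pair differing in one place has been measured, so no measured step is known.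

Compound 3 `Cc1ccc(=O)n(CCC(=N)S)n1` is not yet measured. Relative to compound 1 it carries methyl in place of thiophen-2-yl on an aromatic carbon. For the measured compounds named here, with no measured step to lean on, the expectation rests on compound 1 alone.

A downward step is expected, a number 25.2 percentage points lower from compound 1 to compound 3 (beyond the scatter), beyond the scatter, since compound 1 at 50.2% is the only anchor. Compound 3 is therefore estimated at 25%, ranging from 5% to 48%.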

Compound 3, a percentage reported as inhibition, in the whole organism at one dose (the size of the read-out at that dose, not a potency): 73.9%
The estimate for compound 3 lay 48.9 percentage points below the measured number, outside the stated range (above it).
By their numbers in this assay, from the lowest: compound 2; then compound 1; then compound 3.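

In this assay the aromatic carbon does not need thiophen-2-yl: the read-out moves by a number 23.7 percentage points higher from compound 1 to compound 3 (beyond the scatter) on exchange for methyl, so the ring can go from this position without loss at the one dose given. A single carbon in place of 5 heavy atoms suffices here. Nothing measured explains the rise.

Still open, as far as these compounds go, is whether an amine, a carboxylic acid or a longer chain such as propyl at this carbon would rise further or fall. Whether the step carries over to other substitution on the shared core also remains unsettled.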